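This account rests on a few compounds, and the source may have more. Where it says the series, first, only, none or still open, it means among the compounds named here.

Measured so far:
compound 1, `O=c1c(C(=S)Nc2ccccc2)coc2ccccc12`: 60600 nM
compound 2, `O=c1c(C2N=C(c3ccccc3)SS2)coc2ccccc12`: > 100000 nM

In a functional assay on PC-3 cells (Homo sapiens) for inhibition, read by sulforhodamine B assay, with a stated time of 48 h (a higher number here means a weaker inhibitor, a lower number a stronger inhibitor), compound 1 gives 60600 nM. Compound 2 reaches only the limit of the assay, > 100000 nM, which is a limit and not a number (the limit of > 100000 nM in this assay, at which 1 of the 2 values shown sits). Compound 3, `O=c1c(C2N=C(c3ccccc3)SS2)coc2cc(Cl)ccc12`, is not yet measured; it differs from compound 2 by chloro in place of hydrogen on an aromatic carbon. Among the measured compounds shown here, no step between measured compounds is known for this change, so in this assay no shift beyond the usual scatter is expected. Compound 3 is therefore estimated at 100000 nM (range 30000 nM to 300000 nM), a step of a number no higher from compound 2 to compound 3 (the limit leaves the size open) that is expected to stay within the scatter.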

Compound 3, half-maximal inhibitory concentration: 38400 nM
Compound 3: the middle estimate sits 2.6-fold (0.42 log units) above what was measured, and the stated range covers the measured number.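

In this assay, chloro in place of hydrogen on an aromatic carbon gives an at least 2.6-fold lower number from compound 2 to compound 3 (0.41 log units; beyond the scatter). This position, meta to a fused ring and para to a fused ring, is thus the first place in the series where a single change is seen to move the number beyond the scatter. Compound 2 stands at a limit and not at a number, so the full size of the step remains open: the limit of > 100000 nM in this assay, at which 1 of the 3 values shown sits.

Open, on these data alone, is whether a fluoro, a methoxy or an amine at this position moves the number as chloro does. Also open, as far as these compounds go, is whether chloro has the same effect on the core of compound 1.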